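A 3,4-dimethylpiperazin-1-yl group replaces 4-acetylpiperazin-1-yl

The source may report more compounds than this note shows. Statements on the series, on what has been measured and on what is new or still open speak of the compounds shown alone.

In a functional assay on DLD-1 cells (Homo sapiens) for inhibition, read by luminescence, with a stated time of 3 days (a higher number here means a weaker inhibitor of growth, a lower number a stronger inhibitor of growth), compound 3 (`CC[C@@H]1CC[C@@H](C(=O)N2CCN(C(C)=O)CC2)N1C(=O)C1=C(C(C)C)N2C(=N[C@@](C)(c3ccc(Cl)cc3)[C@H]2c2ccc(Cl)cc2)S1`) gives 9300 nM. Its neighbour compound 1 (`CC(=O)N1CCN(C(=O)[C@@H]2CC[C@@H](C)N2C(=O)C2=C(C(C)C)N3C(=N[C@@](C)(c4ccc(Cl)cc4)[C@H]3c3ccc(Cl)cc3)S2)CC1`) gives 16000 nM, which lies within the scatter of compound 3, while compound 2 (`CC[C@@H]1CC[C@@H](C(=O)N2CCN(C)CC2)N1C(=O)C1=C(C(C)C)N2C(=N[C@@](C)(c3ccc(Cl)cc3)[C@H]2c2ccc(Cl)cc2)S1`) gives 4000 nM, which lies beyond it on the side of stronger growth inhibition.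

Compound 4 (`CC[C@@H]1CC[C@@H](C(=O)N2CCN(C)[C@H](C)C2)N1C(=O)C1=C(C(C)C)N2C(=N[C@@](C)(c3ccc(Cl)cc3)[C@H]2c2ccc(Cl)cc2)S1`) has not yet been measured. It differs from compound 3 at one place, with 3,4-dimethylpiperazin-1-yl in place of 4-acetylpiperazin-1-yl on a carbonyl carbon.

The closest guide is compound 2, where acetyl in place of methyl on an amine nitrogen in a ring gave a 2.3-fold higher number from compound 2 to compound 3 (0.37 log units; beyond the scatter). Read backwards, that step covers the loss of the acetyl in compound 4. Among the compounds with values here, the second methyl of the new group has no measured counterpart on this ring. Within the data shown here, the only other methyl step, on a saturated chain carbon, is a 1.7-fold lower number from compound 1 to compound 3 (0.24 log units; within the scatter), so compound 1 offers no sign of a large methyl effect, though it concerns a different place.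

A modest move toward a lower number is therefore expected, and the expected step is a 2.2-fold lower number from compound 3 to compound 4 (0.35 log units; beyond the scatter). For compound 4 the estimate is 4200 nM, with an expected range of 1800 nM to 9500 nM.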

Compound 4, concentration for 50% growth inhibition: 3600 nM
Compound 4: the middle estimate sits 1.2-fold (0.07 log units) above what was measured, and the stated range covers the measured number.
By their numbers in this assay, from the lowest: compounds 4 and 2 (each within the scatter of the next); then compounds 3 and 1 (each within the scatter of the next).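

In this assay, putting 3,4-dimethylpiperazin-1-yl in place of 4-acetylpiperazin-1-yl on this carbonyl carbon gives a 2.6-fold lower number from compound 3 to compound 4 (0.41 log units; beyond the scatter), so the full exchange lowers the number by a step beyond the scatter, even with the added methyl and the one defined stereocentre it brings. The earlier compounds shown here gave no reading for that methyl on this ring, and the new comparison supplies one: a 1.1-fold lower number from compound 2 to compound 4 (0.05 log units; within the scatter), which shows that methyl in place of hydrogen on a saturated ring carbon makes no change that can be read here, leaving compound 4 level with compound 2 within the scatter. Nothing measured here accounts for these steps in the number for growth inhibition.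

The compounds shown leave open how the opposite configuration at the new stereocentre would read, and whether a free secondary amine or an ethyl group on that ring nitrogen would read like the methyl. They also leave open whether the 3,4-dimethylpiperazin-1-yl group would give a similar step on the core of compound 1.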